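The source may report more compounds than this note shows. Statements on the series, on what has been measured and on what is new or still open speak of the compounds shown alone.

Among the measured compounds shown here, in a functional assay on HepG2 cells (Homo sapiens) for antiproliferative activity, read by MTT assay, with a stated time of 48 h (a lower number here means a stronger inhibitor, a higher number a weaker inhibitor), compound 2 `Cc1ccc(-c2nc(NN)c3cc(Cl)ccc3n2)cc1` gives 4.17 ug/mL, the lowest of the two numbers measured so far. For the measured compounds named here, its nearest neighbour is compound 1 `Cc1ccc(-c2nc(N)c3cc(Cl)ccc3n2)cc1`, which in this assay gives 14.5 ug/mL; the two differ only by the amino group on the ring nitrogen, and the step of a 3.5-fold lower number from compound 1 to compound 2 (0.54 log units; beyond the scatter) is the one measured step in the set. Compound 3 `Cc1ccc(-c2nc(NC(=O)c3ccccc3)c3cc(Cl)ccc3n2)cc1` has not yet been measured in this assay. It differs from compound 2 in one place: benzoyl in place of amino on a nitrogen on an aromatic ring. Going by the values given here, no measured pair shows a benzoyl group entering at this position, so the only step that bears on the change is a 3.5-fold lower number from compound 1 to compound 2 (0.54 log units; beyond the scatter), which records a modest gain on adding the amino group. Compound 3 gives up that amino group and takes on a benzoyl group instead, so the expectation for compound 3 in this assay is a modest step of a 2.2-fold higher number from compound 2 to compound 3 (0.33 log units; beyond the scatter) back toward the number of compound 1. Compound 3 is therefore estimated at 9 ug/mL, within a range from 3 ug/mL to 27 ug/mL.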

Compound 3, half-maximal inhibitory concentration: 17.5 ug/mL
Estimate against measurement, compound 3: 1.9-fold (0.29 log units) below; measured number inside the range.
By their numbers in this assay, from the lowest: compound 2; then compounds 1 and 3 (each within the scatter of the next).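

In this assay, the lower number gained with the amino group on this nitrogen does not survive the exchange for benzoyl, which gives a 4.2-fold higher number from compound 2 to compound 3 (0.62 log units; beyond the scatter). Set against the plain hydrogen of the core, the same benzoyl group gives a 1.2-fold higher number from compound 1 to compound 3 (0.08 log units; within the scatter), so this larger group with its six-membered aromatic ring leaves no readable change from compound 1, and of the three substituents shown on this nitrogen, only the amino group of compound 2 stands apart from the other two compounds. Nothing measured on these compounds speaks to a cause for either step.

The compounds shown leave open whether the lower number of compound 2 depends on the amino group itself or would also appear with another small group on this nitrogen, such as methyl or acetyl. They also leave open whether the benzoyl result is tied to the aromatic ring of that group, which a comparison with an open-chain acyl group such as butanoyl, or with a benzyl group lacking the carbonyl, would begin to address.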